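Piperazine swap on the difluorinated quinoline-ether urea series

A few compounds are considered here, and "the series" means these few. Any claim that something is new, unique, unknown or untested is made for them only; others in the source may bear on it.

Measured compounds:
compound 1 `COc1cc2c(Oc3ccc(NC(=O)NN4C(=O)CSC4c4c(F)cccc4F)cc3Cl)ccnc2cc1OCCCN1CCCC1`: "not determined" (no result reported)
compound 2 `CCN1CCN(CCCOc2cc3nccc(Oc4c(F)cc(NC(=O)NN5C(=O)CSC5c5c(F)cccc5F)cc4F)c3cc2OC)CC1`: 3100 nM
compound 3 `COc1cc2c(Oc3c(F)cc(NC(=O)NN4C(=O)CSC4c4c(F)cccc4F)cc3F)ccnc2cc1OCCCN1CCc2sccc2C1`: "not determined" (no result reported)

Within a functional assay on MDA-MB-231 cells (Homo sapiens) for antiproliferative activity, read by MTT assay, with a stated time of 72 h (a higher number here means a weaker inhibitor, a lower number a stronger inhibitor), only compound 2 carries a number; in that assay compound 2 gives 3100 nM. In the same assay compound 1 gives "not determined" (no result reported) and compound 3 gives "not determined" (no result reported), so compound 3 stands nowhere on the numbers at present: it has no value of its own, and the one further entry without a number, compound 1, gives no anchor either.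

The step from compound 3 to compound 4 `COc1cc2c(Oc3c(F)cc(NC(=O)NN4C(=O)CSC4c4c(F)cccc4F)cc3F)ccnc2cc1OCCCN1CCN(C)CC1` is a change at the end of the chain: a group of 7 heavy atoms (5 carbon, 2 nitrogen; one six-membered non-aromatic ring with 2 hetero atoms) in place of a group of 9 heavy atoms (7 carbon, 1 nitrogen, 1 sulfur; one five-membered aromatic ring with 1 hetero atom, one six-membered non-aromatic ring with 1 hetero atom), on a saturated chain carbon, three bonds along the chain from an oxygen on an aromatic ring. Going by the values given here, no measured pair in the set carries this same change, so no step size can be read off for it, in either direction. Compound 2 already bears a piperazine on the same chain and differs from compound 4 only at the small alkyl group on its far nitrogen, so the value of compound 2, 3100 nM, is the nearest reference point available.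

Because compound 2 gives 3100 nM in this assay, compound 4 is expected to fall close to that reference, at about 3000 nM, with a plausible range from 1000 nM to 9000 nM.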

Compound 4, half-maximal inhibitory concentration: 4360 nM
For compound 4 the middle estimate is 1.5-fold (0.16 log units) below the measured one; the range from low to high includes it.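

In this assay, going by these compounds alone, the change of hydrogen in place of methyl on a saturated chain carbon bound to an amine nitrogen in a ring gives a 1.4-fold higher number from compound 2 to compound 4 (0.15 log units; within the scatter); at this end of the chain, the two piperazine compounds therefore read alike, and this is the first readable comparison. With 4-methylpiperazin-1-yl on the saturated chain carbon, three bonds along the chain from an oxygen on an aromatic ring, compound 4 adds a second piperazine value to that of compound 2, but the step from compound 3 to compound 4 and any other step involving compound 1 cannot be read, as neither compound 1 nor compound 3 has a number. No measurement is at hand that offers an explanation for this result.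

On these data alone, how a morpholine, a dimethylamino group or a piperazine with a free amine hydrogen would read at the end of the same chain remains open. As far as these compounds go, a longer chain leading to the 4-methylpiperazin-1-yl group is equally open, and two piperazine compounds set no trend for the series.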